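Swapping Trimethoxyphenyl for Bromophenyl on the Isoxazole Arm

The source may hold more compounds than are shown below. What is called first, only, known or untested is meant among the compounds shown, and "the series" means these compounds.

Compound 1 `COc1ccc(-c2cc(CN(c3nc4ccc(F)cc4s3)c3nc4ccc(OC)cc4s3)on2)cc1`: 138000 nM
Compound 2 `COc1ccc2nc(N(Cc3cc(-c4cc(OC)c(OC)c(OC)c4)no3)c3nc4ccc(F)cc4s3)sc2c1`: 44000 nM

In a functional assay on U-937 cells (Homo sapiens) for antiproliferative activity, read by MTT assay (a lower number here means a stronger inhibitor, a higher number a weaker inhibitor), compound 2 gives 44000 nM, the lowest of the two numbers; its nearest neighbour is compound 1 with 138000 nM. Compound 3 `COc1ccc2nc(N(Cc3cc(-c4ccc(Br)cc4)no3)c3nc4ccc(F)cc4s3)sc2c1` differs from compound 2 by 4-bromophenyl in place of 3,4,5-trimethoxyphenyl on an aromatic carbon. Among the compounds with values here, the only measured step that bears on this position is a 3.1-fold lower number from compound 1 to compound 2 (0.50 log units; beyond the scatter), where adding methoxy groups lowered the number. Removing all of them and placing bromine instead is expected to push the number back up, probably to the region of compound 1 or somewhat beyond, so the step of a 2.5-fold higher number from compound 2 to compound 3 (0.40 log units; beyond the scatter) is estimated. For compound 3 the expected value is 110000 nM, with a range from 30000 nM to 400000 nM.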

Compound 3, half-maximal inhibitory concentration: 34900 nM
Compound 3: middle estimate off by 3.2-fold (0.50 log units), on the high side; the measured number falls inside the stated range.
By their numbers in this assay, from the lowest: compounds 3 and 2 (each within the scatter of the next); then compound 1.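

On this aromatic carbon, the 3,4,5-trimethoxyphenyl group is not required for the number reached by compound 2: 4-bromophenyl, with no hydrogen-bond acceptors, gives a result within the scatter (a 1.3-fold lower number from compound 2 to compound 3 (0.10 log units; within the scatter)). Bromo in place of the methoxy of compound 1 gives a 4.0-fold lower number from compound 1 to compound 3 (0.60 log units; beyond the scatter) and so, among these compounds, a lower number does not depend on adding methoxy groups. Nothing available explains either step. Still open, on these data alone, is how an unsubstituted phenyl, or a phenyl carrying an amine or a carboxylic acid in place of bromo, would compare.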